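The source may hold more compounds than are shown below. What is called first, only, known or untested is meant among the compounds shown, and "the series" means these compounds.

Compound 1 `Cc1ccc(-c2c(C)nn(-c3nc(-c4ccc(Cl)c(Cl)c4)c(SC(C)C)s3)c2C(=O)O)cc1`: 3800 nM
Compound 2 `COc1cc(C#N)cc(-c2c(C)nn(-c3nc(-c4ccc(Cl)c(Cl)c4)c(SC(C)C)s3)c2C(=O)O)c1`: 5200 nM

Of the compounds shown here, two have been measured in a functional assay on BJAB cells (Homo sapiens) for antiproliferative activity, with a stated time of 4 days; on this read-out lower numbers stand for an effect already at smaller amounts and higher numbers for an effect only at larger amounts of compound. Compound 1 and compound 2 share a core and differ only in the aryl group on the five-membered ring; their numbers are not separated beyond the scatter, as the step of a 1.4-fold higher number from compound 1 to compound 2 (0.14 log units; within the scatter) shows, so neither can be called the more or less active of the pair.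

Compound 3 `Cc1nn(-c2nc(-c3ccc(Cl)c(Cl)c3)c(SC(C)C)s2)c(C(=O)O)c1-c1ccccc1[N+](=O)[O-]` is the next member and has not been measured. Its change relative to compound 2 is 2-nitrophenyl in place of 3-cyano-5-methoxyphenyl on an aromatic carbon. Among the compounds with values here, the only step that bears on this change is the one from compound 1 to compound 2, which exchanged the aryl group at the same place and stayed within the scatter. On that basis compound 3 is expected to show no step beyond the scatter, with a 1.2-fold lower number from compound 2 to compound 3 (0.06 log units; within the scatter) as the estimated change. For compound 3 the estimate is 4500 nM, within a range from 1500 nM to 14000 nM.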

Compound 3, half-maximal effective concentration: 4700 nM
Beside the measured number, compound 3's estimate is 1.0-fold (0.02 log units) below it; the measured number falls inside the stated range.
By their numbers in this assay, from the lowest: compounds 1, 3 and 2 (each within the scatter of the next).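

In this assay, a third aryl group at this place again gives no step beyond the scatter, with 2-nitrophenyl showing both a 1.1-fold lower number from compound 2 to compound 3 (0.04 log units; within the scatter) and a 1.2-fold higher number from compound 1 to compound 3 (0.09 log units; within the scatter). The earlier pair covered only 4-methylphenyl and 3-cyano-5-methoxyphenyl, whereas the three compounds now carry substituents at differently numbered ring positions of the phenyl group, and none of the three stands apart from the others. No evidence at hand explains this lack of separation.

The compounds shown leave open whether an unsubstituted phenyl, an aryl group bearing an amine, or a small alkyl chain in place of the aryl group would also stay within the scatter. They also leave open whether the same holds if an amide replaces the carboxy group on the shared core.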